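Tert-butoxy in place of 1H-pyrazol-1-yl: clearance notes

The compounds below may be only part of what the source reports. "The series", "measured", "known", "first", "only" and "open" are said of these compounds alone.

In an ADME assay on liver for metabolic stability, with Liver microsome (Homo sapiens) as the target, read by LC-MS, using microsomes (on this read-out higher numbers stand for fast clearance and lower numbers for slow clearance), compound 3 (`O=C(NCc1cc(Cl)ccc1-n1cnnn1)[C@@H]1C[C@@H]2C[C@@H]2N1C(=O)[C@H](O)Cn1cccn1`) gives < 12 mL.min-1.g-1, which is a limit. Compound 1 (`O=C(NCc1cc(Cl)ccc1-n1cnnn1)[C@@H]1C[C@@H]2C[C@@H]2N1C(=O)[C@H](O)CC1CC1`) gives < 12 mL.min-1.g-1, also a limit. Compound 2 (`O=C(NCc1cc(Cl)ccc1-n1cnnn1)[C@@H]1C[C@@H]2C[C@@H]2N1C(=O)[C@H](O)c1cccc(Cl)c1`) gives > 500 mL.min-1.g-1, again a limit. Compound 4 (`CC(C)(C)OC[C@@H](O)C(=O)N1[C@H](C(=O)NCc2cc(Cl)ccc2-n2cnnn2)C[C@@H]2C[C@@H]21`) differs from compound 3 as follows: tert-butoxy in place of 1H-pyrazol-1-yl on a saturated chain carbon, two bonds along the chain from a carbonyl carbon and an oxygen on a saturated carbon. Among the measured compounds shown here, three measured steps bear on this change. The closest is a step that the two limits leave unreadable from compound 1 to compound 3, and it offers no size. The large ones, an at least 41-fold higher number from compound 1 to compound 2 (1.61 log units; beyond the scatter) and an at least 41-fold lower number from compound 2 to compound 3 (1.61 log units; beyond the scatter), both involve the 3-chlorophenyl of compound 2, which compound 4 lacks, so no jump of that size is expected. A modest rise in this assay is expected, with an estimated at least 1.6-fold higher number from compound 3 to compound 4 (0.22 log units; that floor lies within the scatter). Compound 4 is estimated at 20 mL.min-1.g-1, within an expected range of 6 mL.min-1.g-1 to 80 mL.min-1.g-1.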

Compound 4, intrinsic clearance in microsomes: 21 mL.min-1.g-1
Estimate against measurement, compound 4: 1.1-fold (0.02 log units) below; measured number inside the range.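

In this assay, among the compounds shown here, compound 4 gives 21 mL.min-1.g-1 as the only value in this set that is not a limit, so tert-butoxy gives this position its first readable number. Both an at least 1.7-fold higher number from compound 3 to compound 4 (0.24 log units; that floor lies within the scatter) and an at least 1.7-fold higher number from compound 1 to compound 4 (0.24 log units; that floor lies within the scatter) leave tert-butoxy unseparated from 1H-pyrazol-1-yl and cyclopropyl. With an at least 23-fold lower number from compound 2 to compound 4 (1.37 log units; beyond the scatter) as the measure, tert-butoxy stays far from the 3-chlorophenyl result.

Open, from the compounds shown here alone, is whether the large rise belongs to 3-chlorophenyl alone or also comes with a plain phenyl at this place. Also open, going by these compounds, is how far the number moves with an amine or a carboxylic acid on the chain.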